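Fluoro for Chloro on the Fused Ring of Compound 2

A few compounds are considered here, and "the series" means these few. Any claim that something is new, unique, unknown or untested is made for them only; others in the source may bear on it.

Compound 1 `CCOC(=O)NC1CC(C)(C)Oc2ccc(Cl)cc21`, compound 2 `CC1(C)CC(NC(=O)Nc2cccc(Cl)c2)c2cc(Cl)ccc2O1` and compound 3 `CC1(C)CC(NC(=O)Nc2ccc(Cl)cc2)c2cc(Cl)ccc2O1` were tested in a functional assay on U-373MG ATCC cells (Homo sapiens) for inhibition, read by MTT assay, with a stated time of 72 h; on this read-out lower numbers stand for stronger inhibition and higher numbers for weaker inhibition. Compound 1 reached only the assay limit, > 100000 nM. Compound 2 gives 21000 nM. Compound 3 gives 19000 nM.

Compound 2 and compound 3 lie within the scatter of each other, as the step of a 1.1-fold lower number from compound 2 to compound 3 (0.04 log units; within the scatter) shows; the third value, that of compound 1, is a limit (the limit of > 100000 nM in this assay, at which 1 of the 3 values shown sits). The move from the carbamate to the ureas gave an at least 4.7-fold lower number from compound 1 to compound 2 (0.67 log units; beyond the scatter) and an at least 5.2-fold lower number from compound 1 to compound 3 (0.72 log units; beyond the scatter).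

Compound 4 `CC1(C)CC(NC(=O)Nc2cccc(Cl)c2)c2cc(F)ccc2O1` is not yet measured. It differs from compound 2 by fluoro in place of chloro on an aromatic carbon. Within the data shown here, none of the measured steps touches this position on the fused ring: the steps from compound 1 change the group on the carbonyl carbon, and the step between compound 2 and compound 3 moves the chloro on the pendant phenyl. Among the measured compounds shown here, the one change of an aryl substituent that is on record, the step from compound 2 to compound 3, stayed within the scatter. With no closer guide, a step within the scatter is expected for compound 4, a 1.2-fold higher number from compound 2 to compound 4 (0.08 log units; within the scatter). Compound 4 is therefore estimated at 25000 nM, between 9000 nM and 70000 nM.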

Compound 4, half-maximal inhibitory concentration: 39000 nM
The estimate for compound 4 lay 1.6-fold (0.19 log units) below the measured number, within the range that was stated.
By their numbers in this assay, from the lowest: compounds 3, 2 and 4 (each within the scatter of the next, the first and the last beyond it). At a limit, above all of these: compound 1.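

Until compound 4, every compound shown carried chloro on the fused ring, so the earlier steps said nothing about this position. In this assay, fluoro in place of chloro gives a 1.9-fold higher number from compound 2 to compound 4 (0.27 log units; within the scatter), so these two halogens cannot be told apart here on this read-out, at least with the 3-chlorophenyl urea on the shared core. No measurement shown here bears on why the swap leaves the number within the scatter.

The compounds shown leave open whether this position needs a halogen at all, and what a hydrogen, a methoxy group, an amine or a carboxylic acid at the same aromatic carbon would do to the number. They also leave open whether fluoro in place of chloro would give a similar result with the 4-chlorophenyl urea of compound 3, or whether larger replacements such as bromo or trifluoromethyl would move the number beyond the scatter.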